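The compounds below may be only part of what the source reports. "The series", "measured", "known", "first", "only" and "open" are said of these compounds alone.

Of the compounds shown here, three have so far been tested in a functional assay on KB cells (Homo sapiens) for inhibition, read by MTT assay, with a stated time of 24 h, tested at 10 ug/mL; a lower number here means less inhibition of growth, a higher number more inhibition of growth at the concentration tested. Compound 1 (`CC(=O)SCCC(CCCCC(=O)O)SC(C)=O`) gives 8.88%, compound 2 (`O=C(O)CCCCC(CCSC(=O)c1ccccc1)SC(=O)c1ccccc1`) gives 2.68%, and compound 3 (`O=C(CCCCC1CCSS1)NO`) gives 0.89%. Compound 3 therefore stands among numbers that repeated measurements could not tell apart. Its value lies within the usual scatter of both of the others, so the three cannot be ranked, and all show little growth inhibition at the concentration tested.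

Compound 4 (`O=C(CCCCC1CCSS1)Nc1ccccn1`) has not yet been measured. It keeps the core of compound 3 and differs only in one group: pyridin-2-yl in place of hydroxy on an amide-type nitrogen. In plain terms, pyridin-2-yl stands in place of hydroxy on an amide-type nitrogen. Going by the values given here, no measured pair of compounds shows a change of this kind, so no earlier step can serve as a guide. The expectation rests only on the low values seen so far, with compound 1 at 8.88% and compound 3 at 0.89%. A small upward move that stays within the scatter is expected, and the estimated step is a number 5.1 percentage points higher from compound 3 to compound 4 (within the scatter). The estimated value for compound 4 is 6%, with an expected range from 0% to 20%.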

Compound 4, percent growth inhibition at one concentration: "not active" (no number reported)
Compound 4 has no reported number here, and the estimate cannot be compared.
By their numbers in this assay, from the lowest: compounds 3, 2 and 1 (each within the scatter of the next).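

In this assay, going by these compounds alone, compound 4 is reported only as "not active", with no number, so no step from compound 3, at 0.89%, can be read. The compounds shown leave open how far pyridin-2-yl in place of hydroxy shifts growth inhibition, and no measurement here speaks to any cause.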